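Arylalkyne propanoic acids: cyclopropyl to 1-methylethenyl

This account rests on a few compounds, and the source may have more. Where it says the series, first, only, none or still open, it means among the compounds named here.

Within the data shown here, compound 1 `O=C(O)CCc1ccc(C#CC2CC2)cc1` gives 128% in a functional assay on 1321-N1 cells for agonist activity at Free fatty acid receptor 1 (Homo sapiens), read by calcium flux, with a stated time of 0.4 s (a higher number here means a larger maximal response, a lower number a smaller maximal response), the higher of the two numbers measured so far. Compound 2 `CCCCCCCC#Cc1ccc(CCC(=O)O)cc1` gives 84% in this assay, a value lying beyond the scatter below that of compound 1. Compound 3 `C=C(C)C#Cc1ccc(CCC(=O)O)cc1` keeps the shared core and differs from compound 1 by 1-methylethenyl in place of cyclopropyl on a triple-bonded carbon. Among the measured compounds shown here, no pair of measured compounds differing in one place exists to anchor this change. A small downward step, roughly within the scatter, is expected: a number 16 percentage points lower from compound 1 to compound 3 (beyond the scatter). Compound 3 is estimated at 112%, with a range from 85% to 138%.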

Compound 3, largest response reached (reported as efficacy), in percent of the reference or control that the assay uses: 108%
The estimate for compound 3 lay 4 percentage points above the measured number, within the range that was stated.
By their numbers in this assay, from the lowest: compound 2; then compound 3; then compound 1.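

In this assay, 1-methylethenyl in place of cyclopropyl on a triple-bonded carbon gives a number 20 percentage points lower from compound 1 to compound 3 (beyond the scatter). This position therefore distinguishes two groups with the same count of heavy atoms, yet the ring is not needed for a high maximal response, as compound 3 gives 108%. Nothing available bears on the reason for this step.

Still open, as far as these compounds go, is how a saturated open group such as isopropyl, or a larger ring such as cyclobutyl, would behave on the same carbon. The compounds shown also leave unsettled whether the ring or the double bond tracks with this step.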